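Benzyloxy variation on the shared core: towards compound 4

A few compounds are considered here, and "the series" means these few. Any claim that something is new, unique, unknown or untested is made for them only; others in the source may bear on it.

Measured so far in a functional assay on B16 cells (Mus musculus) for antiproliferative activity, read by MTT assay, with a stated time of 24 h; a higher number here means a weaker inhibitor, a lower number a stronger inhibitor:
compound 1 `COc1cc(OC)c(-c2coc3cc(OCC=C(C)C)ccc3c2=O)cc1OC` gives 1090 nM
compound 2 `COc1cc(OC)c(-c2coc3cc(OCc4ccc(F)cc4)ccc3c2=O)cc1OC` gives 1120 nM
compound 3 `COc1cc(OC)c(-c2coc3cc(OCc4cccc(F)c4)ccc3c2=O)cc1OC` gives 2440 nM

Compound 2 stands second highest of the three numbers in this assay. Its nearest neighbour is compound 1, and that pair lies within the scatter (a 1.0-fold higher number from compound 1 to compound 2 (0.01 log units; within the scatter)), so no order between them is claimed. Its furthest neighbour is compound 3, reached by a 2.2-fold higher number from compound 2 to compound 3 (0.34 log units; beyond the scatter), a modest step beyond the scatter.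

Compound 4 `COc1cc(OC)c(-c2coc3cc(OCc4cccc(Br)c4)ccc3c2=O)cc1OC` is the next member, differing from compound 2 by 3-bromophenyl in place of 4-fluorophenyl on a saturated chain carbon bound to an oxygen on an aromatic ring.

For the measured compounds named here, two measured steps bear on this. Most directly, a 2.2-fold higher number from compound 2 to compound 3 (0.34 log units; beyond the scatter) shows the same 4-fluorophenyl exchanged for 3-fluorophenyl, giving a modest rise in the number. Consistent with it, a 2.2-fold higher number from compound 1 to compound 3 (0.35 log units; beyond the scatter) also ends at 3-fluorophenyl with a modest rise. Going by the values given here, no measured pair sets bromine against fluorine on this phenyl, so that part of the change rests on nothing here. The expectation is therefore a modest step towards a higher number, a 2.0-fold higher number from compound 2 to compound 4 (0.29 log units; within the scatter), with wide uncertainty.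

Compound 4 is estimated at 2200 nM in this assay, expected between 1100 nM and 4500 nM.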

Compound 4, half-maximal inhibitory concentration: 4400 nM
For compound 4 the middle estimate is 2.0-fold (0.30 log units) below the measured one, and the stated range covers the measured number.
By their numbers in this assay, from the lowest: compounds 1 and 2 (each within the scatter of the next); then compounds 3 and 4 (each within the scatter of the next).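

In this assay, 3-bromophenyl in place of 4-fluorophenyl on a saturated chain carbon bound to an oxygen on an aromatic ring gives a 3.9-fold higher number from compound 2 to compound 4 (0.59 log units; beyond the scatter), and the same group in place of 2-methylprop-1-en-1-yl gives a 4.0-fold higher number from compound 1 to compound 4 (0.61 log units; beyond the scatter), both modest steps beyond the scatter. The series now has its first direct exchange of bromo for fluoro on an aromatic carbon, and a 1.8-fold higher number from compound 3 to compound 4 (0.26 log units; within the scatter) lies within the scatter, so no order is claimed between the 3-bromophenyl and 3-fluorophenyl compounds. Among these four compounds, compounds 3 and 4, with the 3-fluorophenyl and 3-bromophenyl groups, both stand at higher numbers than compounds 1 and 2 by steps beyond the scatter, and none of the four goes against this split.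

On these data alone, whether an amine or a carboxylic acid on this phenyl, or a longer chain in place of the benzyl link to the oxygen, would keep the numbers in this range remains open. Nothing shown here accounts for the size or direction of these steps.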